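Replacing an amide by a sulfonamide on a shared core

The compounds below may be only part of what the source reports. "The series", "measured", "known", "first", "only" and "open" are said of these compounds alone.

Of the compounds shown here, three sharing one core have been tested in a functional assay on HL-60 cells (Homo sapiens) for antiproliferative activity, read by MTT assay, with a stated time of 72 h; a higher number here means a weaker inhibitor, a lower number a stronger inhibitor. Compound 1 `CN(C(=O)C(C)(C)C)c1ccc2[nH]c(-c3n[nH]c4ccccc34)cc2n1` gives 4990 nM. Compound 2 `CN(C(=O)CCc1ccccc1)c1ccc2[nH]c(-c3n[nH]c4ccccc34)cc2n1` gives 4730 nM, and compound 3 `CN(C(=O)c1ccc([N+](=O)[O-])cc1)c1ccc2[nH]c(-c3n[nH]c4ccccc34)cc2n1` gives 6800 nM. The distances between them are small: a 1.1-fold lower number from compound 1 to compound 2 (0.02 log units; within the scatter), a 1.4-fold higher number from compound 1 to compound 3 (0.13 log units; within the scatter) and a 1.4-fold higher number from compound 2 to compound 3 (0.16 log units; within the scatter), so compound 2, though it carries the smallest of the three numbers, is not separated from either neighbour beyond the scatter. Every step measured so far swaps the group on the carbonyl carbon of the amide, tert-butyl, phenethyl or 4-nitrophenyl, and none of these swaps moves the number.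

Compound 4 `Cc1ccc(S(=O)(=O)N(C)c2ccc3[nH]c(-c4n[nH]c5ccccc45)cc3n2)cc1` differs from compound 2 in another way: (4-methylphenyl)sulfonyl in place of phenethylcarbonyl on a nitrogen on an aromatic ring. Here the carbonyl itself goes and a sulfonyl arrives, a change of kind that no measured pair covers directly. Going by the values given here, the only guidance is indirect: the three amides, whatever sits on their carbonyl carbon, give one and the same number within the scatter, which suggests that this part of the molecule tolerates variation without a large effect on this assay.

On that basis, compound 4 is expected to stay close to compound 2, with a step of a 1.1-fold higher number from compound 2 to compound 4 (0.02 log units; within the scatter) that does not clearly exceed the scatter. The estimate for compound 4 in this assay is 5000 nM, with a range from 2000 nM to 12500 nM.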

Compound 4, half-maximal inhibitory concentration: 3030 nM
For compound 4 the middle estimate is 1.7-fold (0.22 log units) above the measured one, and the stated range covers the measured number.
By their numbers in this assay, from the lowest: compounds 4, 2, 1 and 3 (each within the scatter of the next, the first and the last beyond it).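

In this assay there is a 1.6-fold lower number from compound 2 to compound 4 (0.19 log units; within the scatter) and a 1.6-fold lower number from compound 1 to compound 4 (0.22 log units; within the scatter) and so the exchange of a carbonyl for a sulfonyl on this nitrogen does not move the number beyond the scatter relative to either of these amides. The earlier compounds shown here showed tolerance only for swaps of the group on the carbonyl carbon, whereas this result extends it to the carbonyl itself, although the printed values of compound 3 at 6800 nM and compound 4 at 3030 nM do lie beyond the scatter of each other. The data shown offer no explanation for how this sulfonyl compares with the amides.

With (4-methylphenyl)sulfonyl as the only sulfonyl group shown, it remains open whether the picture holds for a sulfonyl carrying a plain methyl or a dimethylamino group instead of the 4-methylphenyl ring. Also open, as far as these compounds go, is what happens on this nitrogen when a urea replaces the amide or when a plain hydrogen takes the place of the whole carbonyl or sulfonyl group.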